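Replacing the furan-2-yl amide in a chalcone series

The source may report more compounds than this note shows. Statements on the series, on what has been measured and on what is new or still open speak of the compounds shown alone.

Compounds measured so far, with their inhibition readings:
compound 1, `COc1cc(/C=C/C(=O)c2cccc(NC(=O)c3ccco3)c2)ccc1O`: 61%
compound 2, `CCCC(=O)Nc1cccc(C(=O)/C=C/c2ccc(O)c(OC)c2)c1`: 40%

Of the compounds shown here, two sharing one core have been tested in a functional assay on HUVEC cells (Homo sapiens) for inhibition, tested at 2.5 ug/mL; a lower number here means a weaker effect, a higher number a stronger effect of the compound at the concentration tested. Compound 1 gives 61% and stands highest of the two numbers; its nearest neighbour, compound 2, gives 40%. Among the measured compounds shown here, the one step among them, a number 21 percentage points lower from compound 1 to compound 2 (beyond the scatter), lies beyond the scatter and is of modest size.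

Compound 3, `COc1cc(/C=C/C(=O)c2cccc(NC(=O)c3c(Cl)cccc3Cl)c2)ccc1O`, has not yet been measured in this assay. It differs from compound 1 in a single place: 2,6-dichlorophenyl in place of furan-2-yl on a carbonyl carbon

For the measured compounds named here, the only measured step that bears on this change is the one from compound 1 to compound 2, where propyl took the place of furan-2-yl on the same carbonyl carbon and the reading fell by a modest amount. Going by the values given here, no measured compound carries 2,6-dichlorophenyl, so the direction for compound 3 rests on that one step alone. Because the step of a number 21 percentage points lower from compound 1 to compound 2 (beyond the scatter) went downward when furan-2-yl was removed, a small loss is expected for compound 3, although a result within the scatter would not be surprising. The estimate for compound 3 in this assay is 50%, within a range from 25% to 75%, which means an expected step of a number 11 percentage points lower from compound 1 to compound 3 (beyond the scatter).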

Compound 3, a percentage reported as inhibition, at one concentration (the size of the read-out at that concentration, not a potency): 53%
Compound 3: middle estimate off by 3 percentage points, on the low side, within the range that was stated.
By their numbers in this assay, from the lowest: compound 2; then compounds 3 and 1 (each within the scatter of the next).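

In this assay, the carbonyl carbon next to the amide-type nitrogen tolerates a much larger change of ring than the earlier pair could show. Exchanging furan-2-yl for 2,6-dichlorophenyl (a number 8 percentage points lower from compound 1 to compound 3 (within the scatter)) gives a reading within the scatter of the original, so the ring oxygen of furan-2-yl is not required for inhibition at this level. The second comparison (a number 13 percentage points higher from compound 2 to compound 3 (beyond the scatter)) shows that the loss seen with propyl does not follow from removing furan-2-yl as such, since compound 2, with its propyl group, reads below both compounds carrying an aromatic ring at this position, although nothing available explains this difference.

The compounds shown leave open whether the two chlorine atoms contribute anything, which a plain phenyl ring would test, and whether a longer chain or a cyclohexyl group would stay with propyl or reach the aromatic compounds. Each reading also comes from a single concentration, so the similar readings of compound 1 and compound 3 leave any difference in potency unresolved.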